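Methoxy for bromo on compound 3: expected effect

The source may hold more compounds than are shown below. What is called first, only, known or untested is meant among the compounds shown, and "the series" means these compounds.

Series notes. Compound 1 `COc1ccc(/C(Cl)=C/C=C(\C#N)C(=O)c2c(C)[nH]c3ccccc23)cc1OC` in a functional assay for inhibition, read by Griess assay, with a stated time of 150 min, tested at 1 mM (a lower number here means less inhibition, a higher number more inhibition at the concentration tested (going by the name of the read-out)), gives 75.8%. Among the measured compounds shown here, compound 2 `COc1cc(/C(Cl)=C/C=C(\C#N)C(=O)c2c(C)[nH]c3ccccc23)cc(OC)c1OC` gives 74.2% in this assay, and the one measured step, a number 1.6 percentage points lower from compound 1 to compound 2 (within the scatter), lies within the scatter. Compound 3 `N#C/C(=C\C=C(/Cl)c1ccc(Br)cc1)C(=O)c1c[nH]c2ccc(Br)cc12` gives 67.5% in this assay; its gaps to compound 1 and to compound 2 are both within the scatter, so the three measured values cannot be ordered.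

Compound 4 `COc1ccc2[nH]cc(C(=O)/C(C#N)=C/C=C(\Cl)c3ccc(Br)cc3)c2c1` differs from compound 3 in one place, (methoxy in place of bromo on an aromatic carbon). For the measured compounds named here, no measured pair in the set shows bromo replaced by methoxy, and the only measured step, from compound 1 to compound 2, concerns methoxy entering for hydrogen on a different ring and was itself within the scatter. The data therefore give no ground for expecting a step beyond the scatter in this assay for compound 4, in either direction.

The expected step of a number 0.5 percentage points higher from compound 3 to compound 4 (within the scatter) is thus estimated as one within the scatter. Compound 4 is expected to give about 68% in this assay, with a range from 55% to 80%.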

Compound 4, a percentage reported as inhibition, at one concentration (the size of the read-out at that concentration, not a potency): 76.7%
Estimate against measurement, compound 4: 8.7 percentage points below; the range from low to high includes it.
By their numbers in this assay, from the lowest: compounds 3, 2, 1 and 4 (each within the scatter of the next).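

In this assay, methoxy in place of bromo on this aromatic carbon of the fused system gives a number 9.2 percentage points higher from compound 3 to compound 4 (within the scatter), the first exchange read at this position; the earlier step concerned methoxy for hydrogen on a different ring. Within this pair, bromo and methoxy therefore cannot be told apart at the single concentration tested, although methoxy brings one more heavy atom and a hydrogen-bond acceptor. Nothing at hand bears on why the two groups read alike.

From the compounds shown here alone, whether an amine or a carboxylic acid on this carbon would also read within the scatter of compound 4 remains open. A read-out at one concentration also leaves open whether the pair would stay indistinguishable in potency.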